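Shortening the chain of a ketone inhibitor of fatty-acid amide hydrolase

A few compounds are considered here, and "the series" means these few. Any claim that something is new, unique, unknown or untested is made for them only; others in the source may bear on it.

Measured compounds:
Compound 1 `O=C(CCCCCCCc1ccccc1)c1nnc(-c2ccccn2)o1`: 0.6 nM
Compound 2 `O=C(CCCCCCc1ccccc1)c1nnc(-c2ccncc2)o1`: 20 nM
Compound 3 `O=C(CCCCCCCc1ccccc1)C(F)(F)F`: 2000 nM

The three measured compounds were tested in an assay on isolated protein for inhibition of Fatty-acid amide hydrolase 1 (Homo sapiens), read by radioligand binding; a lower number here means a stronger inhibitor, a higher number a weaker inhibitor. Compound 1 gives the lowest number of the three; compound 2 is its nearest neighbour, with a step beyond the scatter, and compound 3 stands furthest away, far beyond the scatter. Compound 1 and compound 3 share the same chain and differ in the group attached to the carbonyl, while compound 2 carries a shorter chain and a different ring on the shared core.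

Compound 4 `O=C(CCCCCc1ccccc1)c1nnc(-c2ccccn2)o1` is the next step: phenyl in place of phenethyl on a saturated chain carbon, five bonds along the chain from a carbonyl carbon. The shared core of compound 1 and the carbonyl are kept; only the chain to the outer ring is cut back. Among the measured compounds shown here, no directly comparable step has been measured. The only hint is that, with a shorter chain than that of compound 1, compound 2 gives 20 nM, though compound 2 also differs in its ring, so the two changes cannot be separated. The expectation is therefore a weaker inhibitor, with the step from compound 1 to compound 4 estimated as a 25-fold higher number from compound 1 to compound 4 (1.40 log units; beyond the scatter). Compound 4 is estimated at 15 nM, within a range of 3 nM to 80 nM.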

Compound 4, half-maximal inhibitory concentration: 4 nM
Beside the measured number, compound 4's estimate is 3.8-fold (0.57 log units) above it; measured number inside the range.
By their numbers in this assay, from the lowest: compound 1; then compound 4; then compound 2; then compound 3.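

In this assay, phenyl in place of phenethyl on a saturated chain carbon, five bonds along the chain from a carbonyl carbon, gives a 6.7-fold higher number from compound 1 to compound 4 (0.82 log units; beyond the scatter), a modest step beyond the scatter. Among the compounds shown here, this is the first reading of chain length alone, since compound 2 also carries a different ring, and it shows that cutting back the chain weakens inhibition while compound 4 still gives 4 nM. Nothing shown here explains the size of this step.

The compounds shown leave open whether a longer chain than that of compound 1 would give a lower or a higher number. They also leave open how a carboxylic acid or an amine in place of the outer phenyl would read on the same core.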